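This account rests on a few compounds, and the source may have more. Where it says the series, first, only, none or still open, it means among the compounds named here.

In an ADME assay on K562 cells (Homo sapiens) for cytotoxicity (a lower number here means a stronger inhibitor, a higher number a weaker inhibitor), compound 1 (`O=C(/C=C/c1ccccc1Cl)c1c(O)c2ccccc2oc1=O`) gives 124 ug/mL. Compound 2 (`O=C(/C=C/c1cccc(Cl)c1)c1c(O)c2ccccc2oc1=O`) has no single number: its result stands as "not determined" (no result reported), so it cannot be ranked against compound 1. In compound 3 (`O=C(/C=C/c1ccc(Cl)cc1Cl)c1c(O)c2ccccc2oc1=O`), 2,4-dichlorophenyl replaces 3-chlorophenyl on a double-bonded chain carbon bound to a double-bonded chain carbon: 2,4-dichlorophenyl in place of 3-chlorophenyl on a double-bonded chain carbon bound to a double-bonded chain carbon. Among the compounds with values here, no measured step is available as a guide, and compound 2 offers no starting number. In this assay, the expectation therefore rests on compound 1 at 124 ug/mL, with no shift beyond the usual scatter in either direction. The expected value for compound 3 is 110 ug/mL, with an estimated range of 45 ug/mL to 260 ug/mL.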

Compound 3, half-maximal inhibitory concentration: 149 ug/mL
Compound 3: middle estimate off by 1.4-fold (0.13 log units), on the low side; the range from low to high includes it.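

In this assay chloro in place of hydrogen on an aromatic carbon gives a 1.2-fold higher number from compound 1 to compound 3 (0.08 log units; within the scatter) and so shows that this ring can carry a second chlorine with no change beyond the usual scatter. The swap of 3-chlorophenyl for 2,4-dichlorophenyl cannot be read directly, as compound 2 has no number. Nothing shown here offers an explanation for the result. Still open, going by these compounds, is whether a quite different group on this ring, such as an amine or a carboxylic acid, would shift the number.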